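A few compounds are considered here, and "the series" means these few. Any claim that something is new, unique, unknown or untested is made for them only; others in the source may bear on it.

Working notes on the series.

Three compounds of this set have numbers in an assay on HEK293 cells for inhibition of acid ceramidase (Homo sapiens), read by fluorescence, with stated times of 10 min and 3 h; a higher number here means a weaker inhibitor, a lower number a stronger inhibitor. Compound 1 `CC(C)CNC(=O)n1c(=O)oc2ccc(C3CCN(C)CC3)cc21` gives 295 nM. Compound 2 `CN1CCC(c2ccc3c(c2)oc(=O)n3C(=O)NCCCCc2ccccc2)CC1=O` gives 105 nM, the lowest of the three numbers shown; its nearest neighbour is compound 1, and compound 3 `CC(C)CNC(=O)n1c(=O)oc2cc(C3CCCN(C)C3)ccc21` lies furthest, with 1750 nM. Both of those gaps sit beyond the usual scatter, so compound 2 stands as the strongest inhibitor among the measured compounds on this evidence.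

Compound 4 `CN1CCC(c2ccc3c(c2)oc(=O)n3C(=O)NCCCCc2ccccc2)CC1` has not yet been measured in this assay. It differs from compound 2 in one place: 1-methylpiperidin-4-yl in place of 1-methyl-2-oxopiperidin-4-yl on an aromatic carbon. Among the compounds with values here, no measured pair in the set isolates this change, so its effect cannot be read off directly; the only related hint is that compound 1, which also carries the 1-methylpiperidin-4-yl group, gives a number that stands nearer to compound 2 than compound 3 does.

Compound 4 is therefore expected to stay close to compound 2, with a step of a 1.4-fold higher number from compound 2 to compound 4 (0.15 log units; within the scatter) that lies within the scatter. The estimate for compound 4 in this assay is 150 nM, with a range from 50 nM to 500 nM.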

Compound 4, half-maximal inhibitory concentration: 129 nM
Compound 4: middle estimate off by 1.2-fold (0.07 log units), on the high side, and the stated range covers the measured number.
By their numbers in this assay, from the lowest: compounds 2 and 4 (each within the scatter of the next); then compound 1; then compound 3.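

At this aromatic carbon, in this assay, 1-methylpiperidin-4-yl in place of 1-methyl-2-oxopiperidin-4-yl gives a 1.2-fold higher number from compound 2 to compound 4 (0.09 log units; within the scatter), and this is the only pair shown that isolates the change. With the rest of the structure held constant, the two groups cannot be told apart in this assay, so on this core the ring carbonyl makes no difference that the measurement can resolve. Nothing at hand bears on why the two groups read alike.

From the compounds shown here alone, whether the same holds with the isobutyl urea chain of compound 1 remains open. Also open, going by these compounds, is how this aromatic carbon responds to other groups, such as piperidin-4-yl with a free ring amine, morpholine, piperazine or a carboxylic acid.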